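The source may hold more compounds than are shown below. What is called first, only, known or untested is meant among the compounds shown, and "the series" means these compounds.

Measured compounds:
- compound 1, `Cc1cccc(C(=O)N[C@@H](CC(C)C)C(=O)NCCNc2ccc(Cl)cc2)c1`: 458 nM
- compound 2, `COc1cccc(C(=O)N[C@@H](CCC2CCCCC2)C(=O)NCCN2CCc3cc(F)ccc32)c1`: 2130 nM

Both numbers come from an assay on isolated protein for inhibition of cathepsin S (Homo sapiens); on this read-out higher numbers stand for weaker inhibition and lower numbers for stronger inhibition. Compound 1 gives 458 nM, and compound 2 gives 2130 nM. Of the two, compound 2 stands at the higher, weaker end: its nearest neighbour is compound 1, whose number is markedly lower, and the gap between them lies beyond the scatter of the assay. The two compounds differ in several places at once, so no single step can be read from that pair.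

Compound 3, `COc1cccc(C(=O)N[C@@H](CCC2CCCCC2)C(=O)N[C@@H](COCc2ccccc2)CN2CCc3cc(F)ccc32)c1`, has not been measured yet. It departs from compound 2 in one place: (benzyloxy)methyl in place of hydrogen on a saturated chain carbon bound to an amide-type nitrogen and a saturated chain carbon. For the measured compounds named here, no measured pair shows this exact change, so the expectation rests on compound 2 alone, starting from its value of 2130 nM. The writer expects the addition to lower the number in this assay, by a step larger than the scatter. The estimated step from a 5.3-fold lower number from compound 2 to compound 3 (0.73 log units; beyond the scatter) expresses that. Accordingly, compound 3 is expected to give about 400 nM in this assay, with a range from 80 nM to 2500 nM.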

Compound 3, inhibition constant: 23 nM
Estimate against measurement, compound 3: 17-fold (1.24 log units) above, outside the stated range (below it).
By their numbers in this assay, from the lowest: compound 3; then compound 1; then compound 2.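

Placing (benzyloxy)methyl in place of hydrogen on this saturated chain carbon, bound to an amide-type nitrogen and a saturated chain carbon, gives a 93-fold lower number from compound 2 to compound 3 (1.97 log units; beyond the scatter) in this assay and shows that the position is far from indifferent to substitution. For the compounds shown here, the earlier pair differed in several places at once, so this is the first change whose effect can be assigned to a single place, and it is a large one, well beyond the scatter. Nothing available here bears on the reason for a step of this size.

The compounds shown leave open how much of the added group the step depends on, since a smaller group at the same carbon, such as methyl, hydroxymethyl or methoxymethyl, would separate the contribution of the ether oxygen from that of the aromatic ring. They also leave open whether the same (benzyloxy)methyl addition would have a comparable effect on the core of compound 1, which carries a different side chain and a different end group.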